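This account rests on a few compounds, and the source may have more. Where it says the series, first, only, none or still open, it means among the compounds named here.

Of the compounds shown here, two have so far been measured in an assay on cells for inhibition of cytochrome P450 11B2, mitochondrial (Homo sapiens); a lower number here means a stronger inhibitor, a higher number a weaker inhibitor. Compound 1 `CC(C)CC1n2cncc2CN(Cc2ccccc2)S1(=O)=O` gives 18.6 nM. Compound 2 `C[C@@H](c1ccc(Cl)cc1)N1Cc2cncn2C(C[C@@H](O)c2ccccc2)S1(=O)=O` gives 2.4 nM, the lower of the two numbers; since these two compounds differ in several places at once, the numbers are all they tell. Compound 3 `COC(C)(C)CC1n2cncc2CN([C@@H](C)c2ccc(Cl)cc2)S1(=O)=O` arises from compound 2 through one change: 1-methoxy-1-methylethyl in place of hydroxy(phenyl)methyl on a saturated chain carbon bound to a saturated ring carbon. Within the data shown here, no single-change step has been measured here, so the size of the step is only a guess. The step of a 2.5-fold higher number from compound 2 to compound 3 (0.40 log units; beyond the scatter) is expected to be a moderate move toward a higher number. Compound 3 is estimated at 6 nM, with a range from 2 nM to 20 nM.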

Compound 3, half-maximal inhibitory concentration: 0.9 nM
Compound 3: middle estimate off by 6.7-fold (0.82 log units), on the high side, outside the stated range (below it).
By their numbers in this assay, from the lowest: compound 3; then compound 2; then compound 1.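

In this assay, putting 1-methoxy-1-methylethyl in place of hydroxy(phenyl)methyl on a saturated chain carbon bound to a saturated ring carbon lowers the number (a 2.7-fold lower number from compound 2 to compound 3 (0.43 log units; beyond the scatter)). So at this position, inhibition does not depend on the six-membered aromatic ring, the hydrogen-bond donor or the defined stereocentre of the group that leaves. Nothing measured here gives a reason for this step. Going by these compounds, whether an amine or a carboxylic acid would be accepted at this position stays open. So does the role of the methoxy oxygen, which a plain 2,2-dimethylpropyl chain could test.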